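Swapping a Methoxyphenyl for a Trifluoromethylphenyl on the Piperazine

A few compounds are considered here, and "the series" means these few. Any claim that something is new, unique, unknown or untested is made for them only; others in the source may bear on it.

Three compounds sharing one core have been examined in an assay on membranes from Cerebral cortex for binding affinity to Adrenergic receptor alpha-1 (Rattus norvegicus), read by radioligand binding; a higher number here means a weaker inhibitor, a lower number a stronger inhibitor. Compound 1 `O=C1CC(=C(c2ccccc2)c2ccccc2)C(=O)N1CN1CCN(c2ccccc2)CC1` reports only a limit in this assay, > 1000 nM. Compound 2 `O=C1CC(=C(c2ccccc2)c2ccccc2)C(=O)N1CCN1CCN(c2ccccc2)CC1` gives 214 nM, and compound 3 `COc1ccccc1N1CCN(CCN2C(=O)CC(=C(c3ccccc3)c3ccccc3)C2=O)CC1` gives 71.5 nM, the lowest of the two numbers in this assay. Compound 4 `O=C1CC(=C(c2ccccc2)c2ccccc2)C(=O)N1CCN1CCN(c2cccc(C(F)(F)F)c2)CC1` is the next in line, and it differs from compound 3 in one place: 3-(trifluoromethyl)phenyl in place of 2-methoxyphenyl on an amine nitrogen in a ring. For the measured compounds named here, no measured step matches this exchange directly. Going by the values given here, the single measured step, a 3.0-fold lower number from compound 2 to compound 3 (0.48 log units; beyond the scatter), bears on it only in part: the methoxy that was added in that step is the group compound 4 gives up, while the trifluoromethyl it takes on has no measured counterpart anywhere in this set. Compound 3 therefore sets the floor of the numbers, and the expectation for compound 4 is a number that climbs back toward compound 2, stated with a wide range on account of the untested trifluoromethyl. The number expected for compound 4 in this assay is 250 nM, between 70 nM and 900 nM. This expectation corresponds to a step of a 3.5-fold higher number from compound 3 to compound 4 (0.54 log units; beyond the scatter).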

Compound 4, inhibition constant: > 1000 nM
Compound 4 was reported as a limit; the forecaster's own chance of this, stated with the estimate: 10%; at least 4.0-fold (0.60 log units) between middle value and limit.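

In this assay, the exchange of 2-methoxyphenyl for 3-(trifluoromethyl)phenyl on an amine nitrogen in a ring does more than undo the gain seen with the methoxy, giving an at least 13-fold higher number from compound 3 to compound 4 (1.14 log units; beyond the scatter), against a 3.0-fold lower number from compound 2 to compound 3 (0.48 log units; beyond the scatter). Set against the plain phenyl, adding a trifluoromethyl gives an at least 4.6-fold higher number from compound 2 to compound 4 (0.66 log units; beyond the scatter), so the two substituents shown on this phenyl move the number in opposite directions, and the loss is not only that of the methoxy. Compound 4 is reported only as a limit, the same one reached by one other compound of the four: the limit of > 1000 nM in this assay, at which 2 of the 4 values shown sit.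

The compounds shown leave open whether the rise belongs to the trifluoromethyl itself or to its place on the phenyl, as the two groups stand on differently named phenyls; a 3-methoxyphenyl or a 2-(trifluoromethyl)phenyl on the same nitrogen would separate the two. Also open, as far as these compounds go, is how a chlorine, a fluorine or a hydroxyl on this phenyl would fall relative to compound 3.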